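A few compounds are considered here, and "the series" means these few. Any claim that something is new, unique, unknown or untested is made for them only; others in the source may bear on it.

Measured compounds in an ADME assay on HEp-2 cells (Homo sapiens) for cytotoxicity, read by CCK-8 assay, with a stated time of 6 days; a higher number here means that more compound is tolerated, a lower number that less compound is tolerated:
- compound 1 `NCCNc1cc(N2CCN(S(=O)(=O)c3ccccc3)CC2)nc2ccccc12` gives 20500 nM
- compound 2 `NCCNc1cc(N2CCN(c3cccc(Cl)c3)CC2)nc2ccccc12` gives 6400 nM
- compound 3 `NCCNc1cc(N2CCN(c3ccccc3Cl)CC2)nc2ccccc12` gives 20800 nM

Standing of compound 3: the step of a 1.0-fold higher number from compound 1 to compound 3 (0.01 log units; within the scatter) lies within the scatter, so the values of compound 1 and compound 3 cannot be told apart; the step of a 3.3-fold higher number from compound 2 to compound 3 (0.51 log units; beyond the scatter) is beyond the scatter, so compound 3 tolerates more compound than compound 2 in this assay.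

Next step: compound 4 `CC(=O)N1CCN(c2cc(NCCN)c3ccccc3n2)CC1` differs from compound 3 as acetyl in place of 2-chlorophenyl on an amine nitrogen in a ring.

Bearing on it are the two steps that exchange the group on the same ring nitrogen: a 1.0-fold higher number from compound 1 to compound 3 (0.01 log units; within the scatter) stayed within the scatter, and a 3.2-fold lower number from compound 1 to compound 2 (0.51 log units; beyond the scatter) was modest. Within the data shown here, no measured step brings an acetyl, or any group without a ring, onto that nitrogen, so the data give no direction for such a change. Given that the exchanges seen so far moved the number by a modest amount at most, a step of no more than modest size is expected, in either direction, and most likely none beyond the scatter.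

Compound 4 is therefore estimated at 20000 nM, with a range from 7000 nM to 55000 nM. This estimate corresponds to an expected step of a 1.0-fold lower number from compound 3 to compound 4 (0.02 log units; within the scatter).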

Compound 4, half-maximal cytotoxic concentration: > 100000 nM
Compound 4 was reported as a limit; the forecaster's own chance of this, stated with the estimate: 20%; at least 5.0-fold (0.69 log units) between middle value and limit.
By their numbers in this assay, from the lowest: compound 2; then compounds 1 and 3 (each within the scatter of the next). At a limit, above all of these: compound 4.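

In this assay compound 4 is reported as a limit, not a number: the limit of > 100000 nM in this assay, at which 1 of the 4 values shown sits.

The group on this ring nitrogen can therefore move the number further than the earlier exchanges showed: an at least 4.8-fold higher number from compound 3 to compound 4 (0.68 log units; beyond the scatter), an at least 4.8-fold higher number from compound 1 to compound 4 (0.68 log units; beyond the scatter) and an at least 15-fold higher number from compound 2 to compound 4 (1.19 log units; beyond the scatter). Acetyl is the only group here without a ring, and phenylsulfonyl, 3-chlorophenyl and 2-chlorophenyl all give lower numbers than it, with no compound shown going against this.

The compounds shown do not separate the absence of a ring from the presence of the carbonyl, which a benzoyl or a methyl on the same nitrogen would help to tell apart. On these data alone, how far the number of compound 4 lies past its limit also remains open.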